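The source may hold more compounds than are shown below. What is called first, only, known or untested is meant among the compounds shown, and "the series" means these compounds.

In an assay for inhibition of protein disulfide-isomerase (Homo sapiens), with a stated time of 1 h (on this read-out lower numbers stand for stronger inhibition and higher numbers for weaker inhibition), compound 1 `CCc1ccc(C(Nc2ccccn2)c2ccc3cccnc3c2O)cc1` gives 170 nM. Compound 2 `Oc1c(C(c2ccc(F)cc2)N2CCCCC2)ccc2scnc12` gives 570 nM. Compound 3 `Oc1c(C(Nc2ccccn2)c2ccc(Cl)cc2)ccc2cccnc12` gives 170 nM; it is level with compound 1, the two together holding the lowest numbers of the three, while compound 2 shows a higher number beyond the scatter. Going by the values given here, the only single-point step in the set, no change at the digits printed from compound 1 to compound 3 (within the scatter), passed without effect. Compound 4 `Oc1c(C(Nc2ccccn2)c2ccccc2F)ccc2cccnc12` differs from compound 3 by 2-fluorophenyl in place of 4-chlorophenyl on a saturated chain carbon bound to an aromatic carbon and a nitrogen on an aromatic ring. Among the compounds with values here, no measured step exchanges one halogenated phenyl for another, and compound 2 carries a different ring partner, so it does not bear directly. Because no change at the digits printed from compound 1 to compound 3 (within the scatter) was flat, the step of a 1.5-fold higher number from compound 3 to compound 4 (0.17 log units; within the scatter) is expected to be small, allowing a modest rise. Compound 4 is therefore estimated at 250 nM, between 100 nM and 650 nM.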

Compound 4, half-maximal inhibitory concentration: 470 nM
Compound 4: the middle estimate sits 1.9-fold (0.27 log units) below what was measured; measured number inside the range.
By their numbers in this assay, from the lowest: compounds 1 and 3 (each within the scatter of the next); then compounds 4 and 2 (each within the scatter of the next).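

In this assay the group on the saturated chain carbon proves sensitive to change, with 2-fluorophenyl giving a 2.8-fold higher number from compound 3 to compound 4 (0.44 log units; beyond the scatter) and a 2.8-fold higher number from compound 1 to compound 4 (0.44 log units; beyond the scatter) even though chloro in place of ethyl gave no change at the digits printed from compound 1 to compound 3 (within the scatter) at the same site. Within these three compounds, 4-chlorophenyl and 4-ethylphenyl hold the lower numbers, and 2-fluorophenyl the higher. No available data account for the rise. The exchange alters both the halogen and its ring position, so the two remain inseparable. A 2-chlorophenyl group on the shared core would separate them.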